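Hydrogen to tert-butyl on the chain of compound 3

The compounds below may be only part of what the source reports. "The series", "measured", "known", "first", "only" and "open" are said of these compounds alone.

The series is followed in an assay on CHO cells for displacement of a labelled ligand from melanin-concentrating hormone receptor 1 (Homo sapiens), read by scintillation counting, with a stated time of 1 h (a lower number here means a stronger inhibitor, a higher number a weaker inhibitor), where three compounds have been measured. Compound 1 `Cc1c(C2CC2)nc2ccc(-n3ccc(OCc4ccc(Cl)cc4)cc3=O)nn12` gives 380 nM, compound 2 `Cc1c(C2CC2)nc2cnc(-n3ccc(OCc4ccc(Cl)cc4)cc3=O)cn12` gives 44 nM, and compound 3 `Cc1nc2ccc(-n3ccc(OCc4ccc(F)cc4)cc3=O)cc2n1C` gives 77 nM. Among these three values compound 3 stands second highest: its nearest neighbour is compound 2, whose value is within the scatter of that of compound 3, while compound 1 sits furthest away, with a higher value that lies beyond the scatter.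

Compound 4 `Cn1c(CC(C)(C)C)nc2ccc(-n3ccc(OCc4ccc(F)cc4)cc3=O)cc21` has not yet been measured. It differs from compound 3 in a single place: tert-butyl in place of hydrogen on a saturated chain carbon bound to an aromatic carbon. Cut one bond further out, the same difference reads methyl to neopentyl.

Within the data shown here, no measured pair in this set shows what such a change does, so the step from compound 3 to compound 4 cannot be anchored to an observed one. The account therefore expects a modest move, if any, and leans toward no change beyond the scatter, since the three measured compounds with their different substituents on the shared core all fall within a narrow band. The step of a 1.3-fold lower number from compound 3 to compound 4 (0.11 log units; within the scatter) is the estimated one. Compound 4 is expected to give about 60 nM, with a range from 18 nM to 200 nM.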

Compound 4, half-maximal inhibitory concentration: > 1000 nM
Compound 4: a limit, no number (the forecaster's own chance of this, stated with the estimate: 3%); middle value at least 16-fold (1.22 log units) away from the limit.
By their numbers in this assay, from the lowest: compounds 2 and 3 (each within the scatter of the next); then compound 1. At a limit, above all of these: compound 4.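

In this assay compound 4 reaches only a limit of the assay, > 1000 nM, and not a number. Among these compounds, the reading is an at least 12-fold higher number from compound 3 to compound 4 (1.11 log units; beyond the scatter), which makes tert-butyl in place of hydrogen on a saturated chain carbon bound to an aromatic carbon the first single change in this set with a readable effect, and that effect is a large loss of inhibition rather than a shift within the scatter. Methyl to neopentyl at this place is therefore not a neutral change on this core, and the true size of the loss stays open on one side: the limit of > 1000 nM in this assay, at which 1 of the 4 values shown sits.

What the compounds shown leave open is how ethyl or isopropyl would read at this place, and so where between methyl and neopentyl the loss sets in. Nor do they tell whether an amine or a carboxylic acid at the end of a chain here would give a like step, or whether the same change would give a like step on the core of compound 2.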